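The compounds below may be only part of what the source reports. "The series", "measured", "known", "first", "only" and "open" are said of these compounds alone.

The shared core of compound 1 `Cc1n[nH]c(C(=O)O)c1Cc1cccc(C(F)(F)F)c1` carries a trifluoromethyl group on its aromatic ring, and in an assay on isolated protein for inhibition of 2-Hydroxyacid oxidase 2 (Rattus norvegicus) (a lower number here means a stronger inhibitor, a higher number a weaker inhibitor), compound 1 gives 300 nM. Two other compounds on the same core have been measured alongside it. Compound 2 `Cc1n[nH]c(C(=O)O)c1Cc1cccc2ccccc12` gives 200 nM in this assay, and compound 3 `Cc1n[nH]c(C(=O)O)c1Cc1ccc(-c2ccc(F)cc2)cc1` gives 400 nM. The three numbers lie within the usual scatter of one another, so the data do not separate compound 1 from either neighbour; its number sits among the others rather than apart from them.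

Compound 4 `Cc1n[nH]c(C(=O)O)c1Cc1cccc(OC(F)(F)F)c1` has not been measured. It differs from compound 1 in one place (trifluoromethoxy in place of trifluoromethyl on an aromatic carbon), on an aromatic carbon of the six-membered carbon ring, meta to a large group. Within the data shown here, no measured pair in this set shows such a change, so nothing in the data points to a step in either direction. The step from compound 1 to compound 4 is therefore expected to be no change at the digits printed from compound 1 to compound 4 (within the scatter), nothing beyond the scatter. Compound 4 is estimated at 300 nM in this assay, with a range from 120 nM to 800 nM.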

Compound 4, half-maximal inhibitory concentration: 700 nM
Compound 4: middle estimate off by 2.3-fold (0.37 log units), on the low side; low and high end bracket the measured number.
By their numbers in this assay, from the lowest: compounds 2, 1, 3 and 4 (each within the scatter of the next, the first and the last beyond it).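

Among these compounds, the step gives the first reading of this position in this assay: on an aromatic carbon meta to a large group, trifluoromethoxy in place of trifluoromethyl gives a 2.3-fold higher number from compound 1 to compound 4 (0.37 log units; beyond the scatter). The step is modest, but it lies beyond the scatter, so this position is not indifferent to the exchange, and here trifluoromethoxy gives the weaker inhibitor of the pair. Nothing available bears on why the number moves.

The compounds shown leave open whether other groups on this carbon, such as methoxy, chlorine or a nitrile, would move the number in the same direction, and how either trifluoromethyl or trifluoromethoxy compares with plain hydrogen there. They also leave open whether the same exchange would give a similar step at another carbon of the ring.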